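Epimer of compound 3 in the cyclopropyl thiazole series

The compounds below may be only part of what the source reports. "The series", "measured", "known", "first", "only" and "open" are said of these compounds alone.

Compound 3 `C[C@@H](NC(=O)c1nc(-c2nccs2)sc1C1CC1)c1ccc(C(=O)NO)cc1` gives 211 nM in an assay on cells for inhibition of protein deacetylase HDAC6 (Homo sapiens), read by fluorescence, with a stated time of 24 h (a higher number here means a weaker inhibitor, a lower number a stronger inhibitor), the highest number among the three measured; compound 1 `C[C@H](NC(=O)c1nc(-c2ncc(-c3ccc(F)cc3)s2)sc1C1CC1)c1ccc(C(=O)NO)cc1` gives 2.02 nM and compound 2 `COc1ccc(-c2cnc(-c3nc(C(=O)N[C@@H](C)c4ccc(C(=O)NO)cc4)c(C4CC4)s3)s2)cc1` gives 2.38 nM. Compound 4 `C[C@H](NC(=O)c1nc(-c2nccs2)sc1C1CC1)c1ccc(C(=O)NO)cc1` differs from compound 3 only in configuration: the two compounds have the same atoms and bonds and differ only in configuration as drawn: 1 of 1 stereo elements differ; a stereocentre at a saturated chain carbon is drawn R in compound 3 and S in compound 4. Among the compounds with values here, no measured pair differs solely in this stereocentre, so nothing bears directly on the step; the only measured step, a 1.2-fold higher number from compound 1 to compound 2 (0.07 log units; within the scatter), concerns a different part of the molecule. Compound 4, though, is drawn with the same configuration as compound 1, whose number is far lower than that of compound 3. A large drop is therefore expected, a 21-fold lower number from compound 3 to compound 4 (1.32 log units; beyond the scatter), and compound 4 is estimated at 10 nM (range 2 nM to 60 nM).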

Compound 4, half-maximal inhibitory concentration: 14 nM
Compound 4: middle estimate off by 1.4-fold (0.15 log units), on the low side, and the stated range covers the measured number.
By their numbers in this assay, from the lowest: compounds 1 and 2 (each within the scatter of the next); then compound 4; then compound 3.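

The stereocentre at the saturated chain carbon carries a large step of its own, a 15-fold lower number from compound 3 to compound 4 (1.18 log units; beyond the scatter), and that step belongs to configuration alone because of one fact: the fact that compounds 3 and 4 differ only in the configuration as drawn.

The aryl group on the aromatic carbon also counts, though its steps are only modest: a 5.9-fold higher number from compound 2 to compound 4 (0.77 log units; beyond the scatter), and a 6.9-fold higher number from compound 1 to compound 4 (0.84 log units; beyond the scatter).

As far as these compounds go, whether the R configuration costs as much with 4-fluorophenyl or 4-methoxyphenyl present remains open. So does the effect of an amine or a carboxylic acid on that aromatic carbon.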